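Tolerance of compound 3 after a sulfamoyl swap

A few compounds are considered here, and "the series" means these few. Any claim that something is new, unique, unknown or untested is made for them only; others in the source may bear on it.

Compound 1 `Cc1cc(/C=C/C#N)cc(C)c1Oc1cc(Nc2ccc(C#N)cc2)c(N)cc1S(N)(=O)=O`: > 21800 nM (a limit)
Compound 2 `COC(=O)c1cc(N)c(Nc2ccc(C#N)cc2)cc1Oc1c(C)cc(CCC#N)cc1C`: > 22700 nM (a limit)

Both compounds were tested in an ADME assay on TZM cells (Homo sapiens) for cytotoxicity, read by XTT assay, with a stated time of 4 days; a higher number here means that more compound is tolerated, a lower number that less compound is tolerated. Compound 2 stands at > 22700 nM, which is a limit and not a number. The other value available is also a limit, so no number places compound 2. Compound 3 `Cc1cc(CCC#N)cc(C)c1Oc1cc(Nc2ccc(C#N)cc2)c(N)cc1S(N)(=O)=O` carries sulfamoyl in place of methoxycarbonyl on an aromatic carbon. Compound 1 also carries sulfamoyl, and its > 21800 nM is a limit too. Going by the values given here, no measured step gives a size for this change, so the expected result in this assay is an at least 1.0-fold lower number from compound 2 to compound 3 (0.01 log units; that floor lies within the scatter), with no change beyond the scatter. Compound 3 is estimated at 21700 nM, with an expected range of 12000 nM to 35000 nM.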

Compound 3, half-maximal cytotoxic concentration: 11100 nM
The estimate for compound 3 lay 2.0-fold (0.29 log units) above the measured number; the whole stated range lies above it.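

In this assay, sulfamoyl in place of methoxycarbonyl on this aromatic carbon, para to a (4-cyanophenyl)amino group, gives an at least 2.0-fold lower number from compound 2 to compound 3 (0.31 log units; beyond the scatter), so this swap costs tolerance. 2-Cyanoethyl in place of 2-cyanoethenyl gives an at least 1.9-fold lower number from compound 1 to compound 3 (0.29 log units; that floor lies within the scatter), a floor that by itself does not separate the two compounds. Compound 2 carries a limit and not a number, so the sulfamoyl step is only a floor: the limit of > 22700 nM in this assay, at which 1 of the 3 values shown sits.

Going by these compounds, the full size of both steps stays open. So does whether a carboxylic acid or a carboxamide on this aromatic carbon would lower the number as sulfamoyl does.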